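Series notes: pyridin-4-yl in place of thiophen-3-yl

This account rests on a few compounds, and the source may have more. Where it says the series, first, only, none or still open, it means among the compounds named here.

Three measured compounds share one core and differ only in the aryl group on the carbonyl carbon. In a functional assay on MCF7 cells (Homo sapiens) for inhibition, read by sulforhodamine B assay, with a stated time of 72 h (on this read-out lower numbers stand for stronger inhibition and higher numbers for weaker inhibition), compound 1 `O=C(/C=C/c1cn(-c2ccccc2)nc1-c1ccsc1)c1ccccc1` gives 1900 nM. In this assay compound 2 `COc1ccc(C(=O)/C=C/c2cn(-c3ccccc3)nc2-c2ccsc2)cc1OC` gives 2800 nM, the highest of the three numbers; the nearest is compound 1 and the furthest is compound 3. The step of a 1.5-fold higher number from compound 1 to compound 2 (0.17 log units; within the scatter) stays within the scatter. In this assay compound 3 `COc1ccc(OC)c(C(=O)/C=C/c2cn(-c3ccccc3)nc2-c2ccsc2)c1` gives 400 nM. The steps of a 4.8-fold lower number from compound 1 to compound 3 (0.68 log units; beyond the scatter) and a 7.0-fold lower number from compound 2 to compound 3 (0.85 log units; beyond the scatter) are both modest but beyond the scatter, so among these three the choice of aryl group on the carbonyl carbon is the only change that has moved the number.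

Compound 4 `COc1ccc(C(=O)/C=C/c2cn(-c3ccccc3)nc2-c2ccncc2)cc1OC` differs from compound 2 in one place: pyridin-4-yl in place of thiophen-3-yl on an aromatic carbon. Among the measured compounds shown here, none of the measured steps touches this position; every measured compound carries the same thiophen-3-yl group, and all three steps concern the aryl on the carbonyl carbon. The expectation for compound 4 therefore rests on the value of compound 2 alone, with no measured guidance on direction, and no step beyond the scatter is assumed. Compound 4 is expected near 2800 nM in this assay, within a wide range from 700 nM to 11000 nM. That estimate corresponds to an expected step of no change at the digits printed from compound 2 to compound 4 (within the scatter).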

Compound 4, half-maximal inhibitory concentration: 4300 nM
For compound 4 the middle estimate is 1.5-fold (0.19 log units) below the measured one; measured number inside the range.
By their numbers in this assay, from the lowest: compound 3; then compounds 1, 2 and 4 (each within the scatter of the next, the first and the last beyond it).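

This position now has its first measured step: in this assay, with the 3,4-dimethoxyphenyl group kept on the carbonyl carbon, pyridin-4-yl in place of thiophen-3-yl gives a 1.5-fold higher number from compound 2 to compound 4 (0.19 log units; within the scatter) at this site. The site, on an aromatic carbon of a five-membered aromatic ring with 2 nitrogen, therefore accepts a six-membered aromatic ring with a ring nitrogen in place of a five-membered aromatic ring with sulfur, with the number staying within the scatter, while the steps beyond the scatter in this set still come only from the aryl group on the carbonyl carbon. Nothing shown offers an explanation for this outcome.

On these data alone, the reading rests on a single pair, so it remains open whether the same replacement would hold with the 2,5-dimethoxyphenyl group of compound 3, which gives 400 nM in this assay and carries thiophen-3-yl. Also open, as far as these compounds go, is how this position would respond to a group of another kind, such as an amine or a carboxylic acid, in place of an aromatic ring.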